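Furanyl in place of bromophenyl on the shared core

The compounds below may be only part of what the source reports. "The series", "measured", "known", "first", "only" and "open" are said of these compounds alone.

Compound 1 `Cc1nc(N)sc1CCCN/C(N)=N/C(=O)NC(C)c1ccc(Br)cc1` is the reference point of this set. Going by the values given here, in an assay on membranes from Sf9 cells for displacement of a labelled ligand from histamine H2 receptor (Homo sapiens), read by scintillation counting, with a stated time of 60 min (on this read-out lower numbers stand for stronger inhibition and higher numbers for weaker inhibition), compound 1 gives 30.2 nM, the lowest of the three numbers measured so far. Among the compounds with values here, compound 3 `Cc1nc(N)sc1CCCN/C(N)=N/C(=O)NC(C)c1ccc(OC(F)(F)F)cc1` gives 126 nM in this assay, and the step of a 4.2-fold higher number from compound 1 to compound 3 (0.62 log units; beyond the scatter) is the only single-point change available. Compound 2 `Cc1nc(N)sc1CCCN/C(N)=N/C(=S)N[C@@H](C)c1ccccc1` differs from compound 1 in more than one place; in this assay compound 2 gives 339 nM, and for this pair only the two values stand side by side, without a single-step comparison.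

Compound 4 `Cc1nc(N)sc1CCCN/C(N)=N/C(=O)NC(C)c1ccco1` has not yet been measured. Relative to compound 1 the change is furan-2-yl in place of 4-bromophenyl on a saturated chain carbon bound to an amide-type nitrogen and a saturated chain carbon. Within the data shown here, no measured step replaces the whole aromatic group, so the nearest guide is a 4.2-fold higher number from compound 1 to compound 3 (0.62 log units; beyond the scatter), which shows that a change confined to the aromatic ring alone already moved the number beyond the scatter. The present change is larger, removing the bromine and the six-membered ring together, and is therefore expected to give a higher number, estimated as a 5.0-fold higher number from compound 1 to compound 4 (0.70 log units; beyond the scatter). Compound 4 is expected to give about 150 nM in this assay, with a range from 45 nM to 500 nM. The measurement will tell whether this holds.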

Compound 4, inhibition constant: 31.6 nM
Compound 4: middle estimate off by 4.7-fold (0.68 log units), on the high side; measured number outside the range, below it.
By their numbers in this assay, from the lowest: compounds 1 and 4 (each within the scatter of the next); then compound 3; then compound 2.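

In this assay the aromatic group on the saturated chain carbon bound to an amide-type nitrogen and a saturated chain carbon can be exchanged whole: furan-2-yl in place of 4-bromophenyl gives a 1.0-fold higher number from compound 1 to compound 4 (0.02 log units; within the scatter) and so leaves the number level with that of compound 1. Neither the bromine nor the six-membered ring is therefore required for a number of this size, whereas the earlier step, with trifluoromethoxy in place of bromo on the same ring, gave a 4.2-fold higher number from compound 1 to compound 3 (0.62 log units; beyond the scatter) and lay beyond the scatter; across these two steps, the extent of the structural change does not set the size of the step. Nothing at hand explains why the two replacements differ in this way.

As far as these compounds go, whether an aromatic ring is needed on this carbon at all remains open, and a cyclohexyl group on the shared core would address that, while a thiophen-2-yl group would test the ring oxygen of furan-2-yl. From the compounds shown here alone, compound 2 carries a plain phenyl group but differs from compound 1 in more than one place, so the effect of removing the bromine alone also stays open.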